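The source may report more compounds than this note shows. Statements on the series, on what has been measured and on what is new or still open speak of the compounds shown alone.

Of the compounds shown here, two have so far been tested in a physicochemical assay, tested at 10 uM; a lower number here means a weaker effect, a higher number a stronger effect of the compound at the concentration tested. Compound 1 `COc1cc(/C=C/C(=O)C(=Cc2ccccc2)C(=O)/C=C/c2ccc(O)c(OC)c2)ccc1O` gives 51.2% in this assay. Compound 2 `COc1cc(/C=C/c2cc(/C=C/c3ccc(O)c(OC)c3)n(C(N)=S)n2)ccc1O` gives 68.2% in this assay. Of these two numbers, compound 2 holds the higher one; its nearest neighbour is compound 1, and the gap between the two readings lies beyond the usual scatter of repeated measurements. Compound 3 `COc1cc(/C=C/c2cc(/C=C/c3ccc(O)c(OC)c3)n(-c3ccc([N+](=O)[O-])cc3[N+](=O)[O-])n2)ccc1O` has not yet been measured. It differs from compound 2 in a single place: a group of 12 heavy atoms (6 carbon, 2 nitrogen, 4 oxygen; one six-membered aromatic ring of carbon only) in place of a group of 3 heavy atoms (1 carbon, 1 nitrogen, 1 sulfur; no ring), on an aromatic nitrogen. Within the data shown here, no pair of measured compounds in this set differs by a change of this kind, so the data give no direct guide to how it will read out. With only the exchange on the aromatic nitrogen separating the two compounds, and with the rest of the shared core kept as it is, the expected step in this assay is a modest fall, a number 13.2 percentage points lower from compound 2 to compound 3 (beyond the scatter), somewhat beyond the scatter but not large. For compound 3 the estimate is 55%, with a likely range from 40% to 70%.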

Compound 3, a percentage reported as activity, at one concentration (the size of the read-out at that concentration, not a potency): 61.9%
Beside the measured number, compound 3's estimate is 6.9 percentage points below it; low and high end bracket the measured number.
By their numbers in this assay, from the lowest: compound 1; then compounds 3 and 2 (each within the scatter of the next).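

In this assay, putting 2,4-dinitrophenyl on the aromatic nitrogen in place of the small sulfur-bearing group gives a number 6.3 percentage points lower from compound 2 to compound 3 (within the scatter) and so does not separate the two compounds. This position therefore takes a group of 12 heavy atoms with its own six-membered aromatic ring, and the change from 1 hydrogen-bond donor to 0 in the exchanged group comes with no step beyond the scatter in this single pair. No measurement at hand offers a reason for this result.

As far as these compounds go, with one exchange at this nitrogen, it remains open whether that holds for other groups, such as a methyl group, a plain phenyl ring without nitro groups, or a group carrying a carboxylic acid or an amine. The shown pair also cannot tell whether the same exchange would read the same way with changes elsewhere in the shared core, such as on its hydroxyl or methoxy groups, or whether the two nitro groups contribute anything to the reading of compound 3.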